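A few compounds are considered here, and "the series" means these few. Any claim that something is new, unique, unknown or untested is made for them only; others in the source may bear on it.

In an assay on HEK293 cells for displacement of a labelled ligand from NPC1-like intracellular cholesterol transporter 1 (Homo sapiens) (on this read-out higher numbers stand for weaker inhibition and lower numbers for stronger inhibition), compound 1 `O=C(CN1CN(c2ccccc2)C2(CCN(C(=O)c3ccc(C4CCCCC4)cc3)CC2)C1=O)NCCCCO` gives 10300 nM, the second highest of the three numbers; compound 2 `CC(C)(C)c1ccc(C(=O)N2CCC3(CC2)C(=O)N(CC(=O)NCCN)CN3c2ccccc2)cc1` gives 7000 nM and compound 3 `CC(C)(C)c1ccc(C(=O)N2CCC3(CC2)C(=O)N(CC(=O)NCCCCO)CN3c2ccccc2)cc1` gives 19200 nM, both of them within the scatter of compound 1. Compound 4 `O=C(CN1CN(c2ccccc2)C2(CCN(C(=O)c3ccc(C4CCCCC4)cc3)CC2)C1=O)NCO` is not yet measured; it differs from compound 1 by hydroxy in place of 3-hydroxypropyl on a saturated chain carbon bound to an amide-type nitrogen. Of the measured steps, a 1.9-fold higher number from compound 1 to compound 3 (0.27 log units; within the scatter) concerns the aromatic carbon and bears little on this change, whereas a 2.7-fold higher number from compound 2 to compound 3 (0.44 log units; beyond the scatter) alters the end of the same chain and is the closer guide. The shortening to hydroxy is therefore expected to shift this assay only modestly, a 1.2-fold higher number from compound 1 to compound 4 (0.07 log units; within the scatter), with no clear direction. Compound 4 is estimated at 12000 nM, within a range of 4000 nM to 40000 nM.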

Compound 4, half-maximal inhibitory concentration: 8300 nM
Beside the measured number, compound 4's estimate is 1.4-fold (0.16 log units) above it; the measured number falls inside the stated range.
By their numbers in this assay, from the lowest: compounds 2, 4, 1 and 3 (each within the scatter of the next, the first and the last beyond it).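

In this assay, going from (4-hydroxybutyl)carbamoyl to (hydroxymethyl)carbamoyl gives a 1.2-fold lower number from compound 1 to compound 4 (0.09 log units; within the scatter) and is the first change shown in which only the length of this chain differs. With the terminal hydroxy kept, the shortened chain therefore leaves the read-out within the scatter, whereas the earlier step at this position changed the chain's end group as well. No available evidence explains this result.

As far as these compounds go, whether a carboxylic acid at the chain end would move the number beyond the scatter remains open. So does the effect of a chain longer than 4-hydroxybutyl.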